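The source may report more compounds than this note shows. Statements on the series, on what has been measured and on what is new or still open speak of the compounds shown alone.

Measured compounds in a functional assay on K562 cells (Homo sapiens) for cytotoxicity, read by MTT assay, with a stated time of 72 h; a lower number here means a stronger inhibitor of growth, a higher number a weaker inhibitor of growth:
compound 1 `NC(=O)c1ccc2c(c1)S(=O)(=O)C=C2` gives 7850 nM
compound 2 `CCCCNC(=O)c1ccc2c(c1)S(=O)(=O)C=C2` gives 2730 nM

Within the data shown here, compound 1 stands at the highest of the two numbers so far; its nearest neighbour is compound 2, and the step is a 2.9-fold lower number from compound 1 to compound 2 (0.46 log units; beyond the scatter), a modest step that exchanges the amide hydrogen for a butyl chain.

Compound 3 `O=S1(=O)C=Cc2ccc(O)cc21` keeps the shared core but carries a different substituent: hydroxy in place of carbamoyl on an aromatic carbon. This change removes the carbamoyl group entirely rather than extending it. Among the measured compounds shown here, the only measured step, a 2.9-fold lower number from compound 1 to compound 2 (0.46 log units; beyond the scatter), concerns substitution on the amide nitrogen of compound 1 and does not bear directly on replacing the whole group with a hydroxy. For the measured compounds named here, no step therefore gives a direct guide; the one available step is modest in size, and both measured numbers lie within a narrow band at the upper end of this assay. Compound 3 is expected to remain in that band, with a step of a 1.1-fold lower number from compound 1 to compound 3 (0.05 log units; within the scatter) from compound 1 that is not expected to exceed the scatter with confidence. The estimate for compound 3 in this assay is 7000 nM, with a range from 2500 nM to 20000 nM.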

Compound 3, concentration for 50% growth inhibition: 51100 nM
For compound 3 the middle estimate is 7.3-fold (0.86 log units) below the measured one, outside the stated range (above it).
By their numbers in this assay, from the lowest: compound 2; then compound 1; then compound 3.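

Working from this assay, the aromatic carbon bearing the carbamoyl group in compound 1 is sensitive to a change of the whole group: the series runs in the weaker direction with a 6.5-fold higher number from compound 1 to compound 3 (0.81 log units; beyond the scatter) and so reverses the direction of the only other step shown, a 2.9-fold lower number from compound 1 to compound 2 (0.46 log units; beyond the scatter) on the amide nitrogen. Carbamoyl and hydroxy match in their counts of hydrogen-bond donors and acceptors, so those counts alone do not hold the number at this place in the series. Nothing measured here accounts for the rise in the number with hydroxy in place of carbamoyl.

Still open, as far as these compounds go, is whether the rise follows the loss of the carbonyl or the presence of the hydroxy itself, which a carboxylic acid, a methoxy group or an amine on the same aromatic carbon could help separate. Also open, from the compounds shown here alone, is whether the gain with butyl on the amide nitrogen continues with a longer chain or with a cyclohexyl group there.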